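Benzyl variation on the piperazine of a sulfonylpyrrolidine series

A few compounds are considered here, and "the series" means these few. Any claim that something is new, unique, unknown or untested is made for them only; others in the source may bear on it.

Measured so far in a functional assay on K562 cells (Homo sapiens) for cytotoxicity, read by MTT assay, with a stated time of 48 h; on this read-out higher numbers stand for weaker inhibition and lower numbers for stronger inhibition:
compound 1 `Cc1cccc(CN2CCN(C(=O)CN[C@H]3CCN(S(=O)(=O)Cc4ccccc4)C3)CC2)c1` gives 11300 nM
compound 2 `O=C(CN[C@H]1CCN(S(=O)(=O)Cc2ccccc2)C1)N1CCN(Cc2ccc(Cl)cc2)CC1` gives 9200 nM
compound 3 `O=C(CN[C@H]1CCN(S(=O)(=O)Cc2ccccc2)C1)N1CCN(Cc2c(Cl)cccc2Cl)CC1` gives 28400 nM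

Compound 1 stands second highest of the three numbers: compound 2 lies within the scatter of it, whereas compound 3 lies beyond it by a 2.5-fold higher number from compound 1 to compound 3 (0.40 log units; beyond the scatter). Compound 4 `COc1ccc(CN2CCN(C(=O)CN[C@H]3CCN(S(=O)(=O)Cc4ccccc4)C3)CC2)cc1` differs from compound 1 in one place: 4-methoxyphenyl in place of 3-methylphenyl on a saturated chain carbon bound to an amine nitrogen in a ring. Among the compounds with values here, two measured steps bear on this. The step of a 1.2-fold lower number from compound 1 to compound 2 (0.09 log units; within the scatter) likewise replaces 3-methylphenyl and stays within the scatter; the step of a 2.5-fold higher number from compound 1 to compound 3 (0.40 log units; beyond the scatter) moves beyond it only with 2,6-dichlorophenyl. Within the data shown here, no measured step brings in 4-methoxyphenyl, so the expectation in this assay is no step beyond the scatter, a 1.1-fold lower number from compound 1 to compound 4 (0.03 log units; within the scatter). Compound 4 is therefore estimated at 10500 nM, with a range from 4500 nM to 25000 nM.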

Compound 4, half-maximal inhibitory concentration: 50900 nM
Estimate against measurement, compound 4: 4.8-fold (0.69 log units) below; the whole stated range lies below it.
By their numbers in this assay, from the lowest: compounds 2 and 1 (each within the scatter of the next); then compounds 3 and 4 (each within the scatter of the next).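

Substitution on this aryl group matters even without 2,6-dichlorophenyl: 4-methoxyphenyl gives a 4.5-fold higher number from compound 1 to compound 4 (0.65 log units; beyond the scatter) and methoxy in place of chloro on an aromatic carbon gives a 5.5-fold higher number from compound 2 to compound 4 (0.74 log units; beyond the scatter) so the identity of the group at one aromatic carbon alone moves the number beyond the scatter. The two weakest entries cannot be separated, with a 1.8-fold higher number from compound 3 to compound 4 (0.25 log units; within the scatter) and so 4-methoxyphenyl and 2,6-dichlorophenyl read alike here. No supporting data explain this shift.

Open, on these data alone, is whether an amine or a carboxylic acid in place of methoxy on that aromatic carbon would stay with compound 2 or with compound 4.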